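Trimethoxyphenyl swap on the chalcone arm of compound 2

The source may hold more compounds than are shown below. What is called first, only, known or untested is meant among the compounds shown, and "the series" means these compounds.

Among the compounds with values here, two chalcone-type analogues on the shared core have numbers so far. Compound 1 `COc1cc(/C=C/C(=O)c2cccc(-n3cc(-c4ccc(Cl)cc4)[nH]c3=O)c2)cc(OC)c1OC` gives 31400 nM in a functional assay on SK-OV-3 cells (Homo sapiens) for inhibition; a lower number here means a stronger inhibitor of growth, a higher number a weaker inhibitor of growth. Compound 2 `COc1ccc(-c2cn(-c3cccc(C(=O)/C=C/c4ccc(O)c(OC)c4)c3)c(=O)[nH]2)cc1` gives 4770 nM in this assay, the lower of the two numbers; compound 1 stands above it by a gap that is beyond the scatter. Compounds 1 and 2 differ in more than one place, so the two values only show where each stands, not what any single change does.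

Compound 3 `COc1ccc(-c2cn(-c3cccc(C(=O)/C=C/c4cc(OC)c(OC)c(OC)c4)c3)c(=O)[nH]2)cc1` is not yet measured. It keeps the core and the 4-methoxyphenyl of compound 2 and changes one place: 3,4,5-trimethoxyphenyl in place of 4-hydroxy-3-methoxyphenyl on a double-bonded chain carbon bound to a double-bonded chain carbon. Within the data shown here, the incoming group is the one carried by compound 1, whose 31400 nM is the weaker of the two known values.

Among the measured compounds shown here, no single-change step is available for this pair. A worsening step from compound 2 to compound 3 is expected, of a size beyond the scatter, since compound 1 with the same 3,4,5-trimethoxyphenyl gives 31400 nM. The expected step is a 3.1-fold higher number from compound 2 to compound 3 (0.50 log units; beyond the scatter). For compound 3 the estimate in this assay is 15000 nM, with a range from 5000 nM to 40000 nM.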

Compound 3, concentration for 50% growth inhibition: 4600 nM
Estimate against measurement, compound 3: 3.3-fold (0.51 log units) above, and the stated range ends above it.
By their numbers in this assay, from the lowest: compounds 3 and 2 (each within the scatter of the next); then compound 1.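

In this assay, 3,4,5-trimethoxyphenyl in place of 4-hydroxy-3-methoxyphenyl on a double-bonded chain carbon bound to a double-bonded chain carbon gives a 1.0-fold lower number from compound 2 to compound 3 (0.02 log units; within the scatter), so with the 4-methoxyphenyl kept, the two groups cannot be told apart at this position, even though the hydrogen-bond donor of the leaving group is absent from the entering group. With 3,4,5-trimethoxyphenyl held constant, methoxy in place of chloro on an aromatic carbon gives a 6.8-fold lower number from compound 1 to compound 3 (0.83 log units; beyond the scatter), so the high number of compound 1 goes with the chloro and not with the trimethoxyphenyl arm. Nothing measured here gives a reason for either step.

Still open, from the compounds shown here alone, is whether the methoxy-for-chloro step has the same size when 4-hydroxy-3-methoxyphenyl sits on the chain, since this pair covers only the 3,4,5-trimethoxyphenyl arm. Also open, going by these compounds, is how far this position tolerates groups of another kind, such as a phenyl ring carrying a dimethylamino group or a carboxylic acid, as both groups compared so far are methoxy-bearing phenyl rings.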